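A few compounds are considered here, and "the series" means these few. Any claim that something is new, unique, unknown or untested is made for them only; others in the source may bear on it.

Working notes on the series, read in an ADME assay on liver (Homo sapiens) for metabolic stability, read by LC-MS, using microsomes and NADPH; on this read-out lower numbers stand for a less stable compound and higher numbers for a more stable compound. Going by the values given here, compound 1 (`COc1cc(CN(CC(C)C)C(CC(=O)O)c2ccc3c(c2)CCO3)ccc1OCCN1C(=O)CCC1=O`) gives 92% and compound 2 (`COc1cc(CN(CC(C)C)C(CC(=O)O)c2ccc(Cl)c(Cl)c2)ccc1OCCN1C(=O)CCC1=O`) gives 75%, so compound 2 holds the lower of the two numbers so far, and the gap lies beyond the scatter. Compound 3 (`COc1cc(CN(CC(C)C)C(CC(=O)O)c2ccc(Cl)cc2Cl)ccc1OCCN1C(=O)CCC1=O`) has not been measured. Its change is 2,4-dichlorophenyl in place of 3,4-dichlorophenyl on a saturated chain carbon bound to an amine nitrogen and a saturated chain carbon. The atoms stay the same and are only joined differently.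

Among the compounds with values here, one measured step bears on this, at the same place: a number 17 percentage points lower from compound 1 to compound 2 (beyond the scatter). That modest step exchanges one whole group for another, whereas here the group keeps its atoms. Within the data shown here, no measured pair shows a change of this narrower kind, so the data give no direction. The expectation therefore stays anchored on compound 2 at 75%, with no step beyond the scatter. The estimated step is no change at the digits printed from compound 2 to compound 3 (within the scatter). Compound 3 is expected at 75%, with an estimated range of 60% to 90%.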

Compound 3, percent of the compound remaining: 57%
Compound 3: middle estimate off by 18 percentage points, on the high side, and the stated range ends above it.
By their numbers in this assay, from the lowest: compound 3; then compound 2; then compound 1.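

In this assay, the arrangement of the two chlorines on the aryl group at this saturated chain carbon matters on its own: with the same atoms joined differently, the read-out gives a number 18 percentage points lower from compound 2 to compound 3 (beyond the scatter). The earlier step could only show one whole group exchanged for another, whereas this one shows that a narrower change at the same place can be of the same modest size, so 3,4-dichlorophenyl and 2,4-dichlorophenyl cannot be treated as interchangeable here. Going by these compounds alone, replacing the group of compound 1 with 2,4-dichlorophenyl gives a number 35 percentage points lower from compound 1 to compound 3 (beyond the scatter), the only large step so far, yet no measurement at hand accounts for either step.

The compounds shown leave open whether the lower number belongs to the arrangement of substituents in 2,4-dichlorophenyl generally or to the two chlorines in particular, a question that 2,4-difluorophenyl and unsubstituted phenyl at the same carbon would help separate. They also leave open whether the step between the two dichlorophenyl groups keeps its direction and size when the rest of the shared core is changed.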